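The source may report more compounds than this note shows. Statements on the series, on what has been measured and on what is new or still open speak of the compounds shown alone.

Measured compounds in a functional assay on the whole organism (strain Swiss) with Mus musculus as the target, in the maximal electroshock model, with a stated time of 0.5 h, at a dose of 300 mg/kg by the intraperitoneal route; a lower number here means a weaker effect, a higher number a stronger effect of the compound at the dose given:
compound 1 `CCC(C(=O)N1CCN(c2ccc(C(F)(F)F)cc2)CC1)N1C(=O)CCC1=O` — 0%
compound 2 `CC(C(=O)N1CCN(c2ccc(C(F)(F)F)cc2)CC1)N1C(=O)CCC1=O` — 25%
compound 3 `CC(C(=O)N1CCOCC1)N1C(=O)CCC1=O` — 0%

Compound 2 stands highest of the three numbers in this assay; compound 1 and compound 3 both lie a step below it, beyond the scatter. Among the measured compounds shown here, the one measured step, a number 25 percentage points higher from compound 1 to compound 2 (beyond the scatter), concerns the saturated chain and not the aromatic ring, so it does not speak directly to the change now at hand. Compound 4 `CC(C(=O)N1CCN(c2ccccc2)CC1)N1C(=O)CCC1=O` differs from compound 2 by hydrogen in place of trifluoromethyl on an aromatic carbon. For the measured compounds named here, no measured step touches that ring, so the data give no firm direction; a modest fall is expected rather than none. Compound 4 is therefore estimated at 15%, in the range 0% to 40%. The expected step is a number 10 percentage points lower from compound 2 to compound 4 (within the scatter).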

Compound 4, a percentage reported as activity, at one dose (the size of the read-out at that dose, not a potency): 50%
The estimate for compound 4 lay 35 percentage points below the measured number; measured number outside the range, above it.
By their numbers in this assay, from the lowest: compounds 1 and 3 (each within the scatter of the next); then compound 2; then compound 4.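

In this assay, hydrogen in place of trifluoromethyl gives a number 25 percentage points higher from compound 2 to compound 4 (beyond the scatter), so the aromatic ring is a place where one change moves the read-out at this dose. The unsubstituted ring does better here than the ring carrying trifluoromethyl, a direction that the step on the saturated chain could not show. The data offer no measured explanation for this rise. From the compounds shown here alone, whether a chlorine atom or a methoxy group at this place would fall nearer compound 2 or compound 4 stays open. So does whether the same change would raise the read-out with the longer chain of compound 1.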